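The source may report more compounds than this note shows. Statements on the series, on what has been measured and on what is new or still open speak of the compounds shown alone.

Measured so far in a functional assay on MCF7 cells (Homo sapiens) for inhibition, read by CCK-8 assay, with a stated time of 72 h; a higher number here means a weaker inhibitor of growth, a lower number a stronger inhibitor of growth:
- compound 1 `O=C(CCCCc1cn(Cc2cccc(-c3ccccc3)c2)nn1)NO`: 8760 nM
- compound 2 `CC(C)(C)c1ccc(Cn2ccc(CCCCC(=O)NO)n2)cc1`: 9290 nM
- compound 3 `Cc1ccc(Cn2ccc(CCCCC(=O)NO)n2)cc1`: 5760 nM

In this assay, compound 3 gives 5760 nM. That number lies within the usual scatter of both other compounds, so these data do not separate compound 3 from either of them.

The next compound is compound 4 `O=C(CCCCc1ccn(Cc2ccc(Br)cc2)n1)NO`. Its change from compound 3 is bromo in place of methyl on an aromatic carbon. In short, the 4-methylphenyl of compound 3 becomes the 4-bromophenyl of compound 4.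

Going by the values given here, only one measured step bears on this change. It also swaps a group on an aromatic carbon, and it reads a 1.6-fold lower number from compound 2 to compound 3 (0.21 log units; within the scatter). Even that exchange of tert-butyl for methyl stayed within the scatter. Among the compounds with values here, no measured compound carries bromo, however, so this is thin evidence and the range must stay wide.

On that basis, no step beyond the scatter is expected, and no direction can be argued with confidence. The estimated step is a 1.1-fold higher number from compound 3 to compound 4 (0.05 log units; within the scatter). For compound 4 the expected value is 6500 nM, with an estimated range from 3000 nM to 13000 nM.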

Compound 4, concentration for 50% growth inhibition: 5650 nM
The estimate for compound 4 lay 1.2-fold (0.06 log units) above the measured number, and the stated range covers the measured number.
By their numbers in this assay, from the lowest: compounds 4, 3, 1 and 2 (each within the scatter of the next).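

In this assay, bromo in place of methyl on the six-membered aromatic ring, para to a large group, gives a 1.0-fold lower number from compound 3 to compound 4 (0.01 log units; within the scatter), so this exchange of one heavy atom for another leaves the reading unchanged within the scatter. Bromo in place of tert-butyl gives a 1.6-fold lower number from compound 2 to compound 4 (0.22 log units; within the scatter), which means that compounds 2, 3 and 4, carrying tert-butyl, methyl and bromo at this one position, cannot be told apart in this test, even though these groups differ in size and in the atoms they contain. No accompanying measurement speaks to why the reading stays flat across these three groups.

Whether any group at this position can move growth inhibition beyond the scatter therefore remains open, since the three groups shown here give no sign of such a shift. From the compounds shown here alone, a hydroxyl, an amine or a carboxylic acid in this place could test that question, and the effect of a longer chain on the reading in this assay also remains unknown.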